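Methyl on the Amide Nitrogen of Compound 3

A few compounds are considered here, and "the series" means these few. Any claim that something is new, unique, unknown or untested is made for them only; others in the source may bear on it.

Of the compounds shown here, three have been measured in an assay on CHO-K1 cells for displacement of a labelled ligand from prostaglandin E2 receptor EP1 subtype (Homo sapiens); on this read-out lower numbers stand for stronger inhibition and higher numbers for weaker inhibition. Compound 1 `Cc1cc(C(=O)O)nn1Cc1cc(Br)ccc1OCc1ccccc1` gives 6.31 nM in this assay, and compound 2 `Cc1cc(C(=O)O)nn1C(C)c1cc(Cl)ccc1OCc1ccccc1` gives 10 nM. Compound 3 `Cc1cc(C(N)=O)nn1Cc1cc(Cl)ccc1OCc1ccccc1` gives 126 nM, the highest of the three numbers, so it is the weakest binder of this set: its gap to compound 2 and its gap to compound 1 both lie beyond the usual scatter. Within the data shown here, compounds 1 and 2 differ from compound 3 in more than one place, so no single structural step connects them, and their values only show where compound 3 sits.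

Compound 4 `CNC(=O)c1cc(C)n(Cc2cc(Cl)ccc2OCc2ccccc2)n1` has not yet been measured. It differs from compound 3 by one change: methyl in place of hydrogen on an amide-type nitrogen. Among the measured compounds shown here, no measured pair shows what this change does here, so the direction is not known from the data in hand. Since compound 3 already gives 126 nM in this assay, the expected step for compound 4 is a small one, with the possibility of a modest weakening; the estimated change from compound 3 to compound 4 is a 1.6-fold higher number from compound 3 to compound 4 (0.20 log units; within the scatter). Compound 4 is therefore expected to give about 200 nM in this assay, with a likely range from 60 nM to 700 nM.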

Compound 4, half-maximal inhibitory concentration: 100 nM
For compound 4 the middle estimate is 2.0-fold (0.30 log units) above the measured one, and the stated range covers the measured number.
By their numbers in this assay, from the lowest: compounds 1 and 2 (each within the scatter of the next); then compounds 4 and 3 (each within the scatter of the next).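

In this assay, among these compounds, methyl in place of hydrogen on the amide-type nitrogen gives a 1.3-fold lower number from compound 3 to compound 4 (0.10 log units; within the scatter) and this is the first measured step at this position. Adding this one carbon leaves the two numbers within the usual scatter of each other, so this read-out cannot tell compound 3 and compound 4 apart, something the earlier compounds could not reveal since neither lies one change from compound 3. Nothing available here offers an explanation for this result.

Going by these compounds, one methyl is only a single small probe, so it remains open whether a longer chain such as ethyl, a second methyl on the same nitrogen, or a cyclopropyl ring would also leave the number within the scatter. Compound 1 and compound 2 carry a carboxylic acid where compound 3 and compound 4 carry an amide, but they also differ from those two elsewhere, so the effect of that exchange alone cannot be read from the compounds shown.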